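The compounds below may be only part of what the source reports. "The series", "measured", "known", "first", "only" and "open" are said of these compounds alone.

Within the data shown here, compound 1 `CCc1cc(C(C)=O)c(O)cc1OCCCCCCC(C)(C)C#N` is the one with the lower number of the two compounds measured so far in an assay on isolated protein for binding affinity to leukotriene B4 receptor (Homo sapiens), tested at 0.1 uM (on this read-out lower numbers stand for less inhibition and higher numbers for more inhibition at the one concentration tested (going by the name of the read-out)), where compound 1 gives 11%. Among the measured compounds shown here, its only measured neighbour, compound 2 `CCc1cc(C(C)=O)c(O)cc1OCCCC(C)(C)c1nnn[nH]1`, carries a 1-(1H-tetrazol-5-yl)-1-methylethyl group in place of the 4-cyano-4-methylpentyl group, and in this assay compound 2 gives 28%, a change described as a number 17 percentage points higher from compound 1 to compound 2 (beyond the scatter).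

Compound 3 `CCc1cc(C(C)=O)c(O)cc1OCCCCCCC(C)(C)c1nnn[nH]1` keeps the full chain of compound 1 and differs from it only at its end: 1H-tetrazol-5-yl in place of cyano on a saturated chain carbon bound to three saturated chain carbons. The step from compound 1 to compound 2 bears on this change, since it too exchanges the cyano group for a tetrazole, but it also shortens the chain, so it is only a partial guide. On that basis a rise of roughly the same order, or somewhat smaller, is expected for compound 3, in the direction of more inhibition.

Compound 3 is therefore expected to give about 25% in this assay, within a range from 10% to 45%. That estimate corresponds to an expected step of a number 14 percentage points higher from compound 1 to compound 3 (beyond the scatter).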

Compound 3, a percentage reported as inhibition, at one concentration (the size of the read-out at that concentration, not a potency): 13%
Compound 3: the middle estimate sits 12 percentage points above what was measured; the measured number falls inside the stated range.
By their numbers in this assay, from the lowest: compounds 1 and 3 (each within the scatter of the next); then compound 2.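

In this assay, with the full chain held constant, the step from nitrile to 1H-tetrazol-5-yl on a saturated chain carbon bound to three saturated chain carbons gives a number 2 percentage points higher from compound 1 to compound 3 (within the scatter) and so does not separate the two end groups on this chain. This is what the earlier pair could not show: the step of a number 17 percentage points higher from compound 1 to compound 2 (beyond the scatter) changes the end group and the chain together, and the present result means that the rise seen there cannot be credited to the tetrazole alone, with compound 3 at 13% and compound 2 at 28% carrying the same end group on different chains. Nothing available explains why the exchange leaves the number within the scatter on the full chain.

The compounds shown leave open how the nitrile behaves on the shorter chain of compound 2, the one comparison that would isolate the chain from the end group. They also leave open whether a carboxylic acid or a primary amide at the same chain end would give a number different from those of the nitrile and the tetrazole, or whether a longer chain would shift the reading further.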